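The source may report more compounds than this note shows. Statements on the series, on what has been measured and on what is new or still open speak of the compounds shown alone.

Values in a functional assay on Jurkat cells (Homo sapiens) for inhibition, read by CCK-8 assay, with a stated time of 48 h (on this read-out lower numbers stand for stronger inhibition of growth and higher numbers for weaker inhibition of growth), for the measured compounds:
- Compound 1 `COc1ccc(CNc2nc(Nc3ccc(N4CCN(C)CC4)cn3)ncc2Cl)cc1` gives 12900 nM
- Compound 2 `COc1ccccc1CNc1nc(Nc2ccc(N3CCN(C)CC3)cn2)ncc1Cl` gives 10800 nM
- Compound 3 `CC(C)c1ccc(Nc2nc(Nc3ccc(N4CCN(C)CC4)cn3)ncc2Cl)cc1` gives 7530 nM

Compound 3 does not stand apart from the other two, as a 1.7-fold lower number from compound 1 to compound 3 (0.23 log units; within the scatter) and a 1.4-fold lower number from compound 2 to compound 3 (0.16 log units; within the scatter) show. Compound 4 `CC(C)c1ccccc1Nc1nc(Nc2ccc(N3CCN(C)CC3)cn2)ncc1Cl` has 2-isopropylphenyl in place of 4-isopropylphenyl on a nitrogen on an aromatic ring. Among the measured compounds shown here, no measured pair makes this exact change. The nearest parallel is 2-methoxyphenyl in place of 4-methoxyphenyl on a saturated chain carbon bound to a nitrogen on an aromatic ring, which gave a 1.2-fold lower number from compound 1 to compound 2 (0.08 log units; within the scatter) in this single case. The expected step is therefore a 1.2-fold lower number from compound 3 to compound 4 (0.06 log units; within the scatter) and none beyond the scatter. Compound 4 is estimated at 6500 nM with an expected range from 3000 nM to 14000 nM in this assay.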

Compound 4, concentration for 50% growth inhibition: 5140 nM
Beside the measured number, compound 4's estimate is 1.3-fold (0.10 log units) above it; the range from low to high includes it.
By their numbers in this assay, from the lowest: compounds 4, 3, 2 and 1 (each within the scatter of the next, the first and the last beyond it).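

In this assay, 2-isopropylphenyl in place of 4-isopropylphenyl gives a 1.5-fold lower number from compound 3 to compound 4 (0.17 log units; within the scatter), so this change on the nitrogen does not clearly separate the two compounds. Compound 4 does clear the scatter against the two methoxybenzyl compounds, though only modestly, with a 2.1-fold lower number from compound 2 to compound 4 (0.32 log units; beyond the scatter) and a 2.5-fold lower number from compound 1 to compound 4 (0.40 log units; beyond the scatter), which compound 3 did not do. No evidence here accounts for these differences. On these data alone, whether an amine or a carboxylic acid in place of the isopropyl group would change growth inhibition in this assay remains open.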